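Trimming the Side Chain: Sec-Butyl to Isopropyl

This account rests on a few compounds, and the source may have more. Where it says the series, first, only, none or still open, it means among the compounds named here.

Of the compounds shown here, three sharing one core have been measured in a functional assay for inhibition, read by spectrophotometry, with a stated time of 20 min, tested at 1 mg/mL; a higher number here means a stronger effect of the compound at the concentration tested, a lower number a weaker effect. Compound 1 `CC(=O)c1ccc(NC(=O)CN(C(=O)c2ccccc2)S(=O)(=O)c2ccc(C)cc2)cc1` gives 17.9%. Compound 2 `CC(=O)c1ccc(NC(=O)C(CC(C)C)N(C(=O)c2ccccc2)S(=O)(=O)c2ccc(C)cc2)cc1` gives 54%. Compound 3 `CCC(C)C(C(=O)Nc1ccc(C(C)=O)cc1)N(C(=O)c1ccccc1)S(=O)(=O)c1ccc(C)cc1` gives 18.6%. On these numbers compound 3 stands second of the three: its reading sits within the scatter of compound 1, as a number 0.7 percentage points higher from compound 1 to compound 3 (within the scatter) shows, while the gap to compound 2 is large, as a number 35.4 percentage points lower from compound 2 to compound 3 (beyond the scatter) shows. Going by the values given here, the only large change seen is a number 36.1 percentage points higher from compound 1 to compound 2 (beyond the scatter).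

Compound 4 `CC(=O)c1ccc(NC(=O)C(C(C)C)N(C(=O)c2ccccc2)S(=O)(=O)c2ccc(C)cc2)cc1` differs from compound 3 by hydrogen in place of methyl on a saturated chain carbon, three bonds along the chain from an amide-type nitrogen and a carbonyl carbon. Among the compounds with values here, no measured step removes a methyl from this side chain, so the expectation rests on indirect evidence: branching on the saturated chain carbon bound to the amide-type nitrogen, which compound 3 carries and compound 2 does not, coincided with a reading near compound 1, whereas the isobutyl of compound 2 coincided with the large rise in a number 36.1 percentage points higher from compound 1 to compound 2 (beyond the scatter). Compound 4 keeps that branching and gives up the methyl, so a change no larger than the scatter, a number 3.4 percentage points higher from compound 3 to compound 4 (within the scatter), is expected. Compound 4 is estimated at 22%, with a range from 8% to 45%.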

Compound 4, a percentage reported as inhibition, at one concentration (the size of the read-out at that concentration, not a potency): 15.6%
Compound 4: middle estimate off by 6.4 percentage points, on the high side; the range from low to high includes it.
By their numbers in this assay, from the lowest: compounds 4, 1 and 3 (each within the scatter of the next); then compound 2.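

Removing the methyl leaves the reading in this assay essentially unchanged (a number 3 percentage points lower from compound 3 to compound 4 (within the scatter)), so sec-butyl and isopropyl cannot be told apart at this position, and the ethyl-to-methyl trim has no visible effect. Isopropyl also cannot be separated from the hydrogen of compound 1 (a number 2.3 percentage points lower from compound 1 to compound 4 (within the scatter)), whereas replacing isobutyl with isopropyl gives a large difference (a number 38.4 percentage points lower from compound 2 to compound 4 (beyond the scatter)), leaving compound 2 alone among these four with the higher reading. No evidence is available to explain this result.

On these data alone, what remains open is whether the higher reading is specific to isobutyl or would also appear with a straight butyl chain or a benzyl group. The compounds shown also leave open how a side chain ending in an amine or a carboxylic acid would read in this assay.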